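This account rests on a few compounds, and the source may have more. Where it says the series, first, only, none or still open, it means among the compounds named here.

Compound 3 `N#CC1=C(N)N(c2ccc(S(N)(=O)=O)cc2)C2=C(CCCC2)C1c1ccc([N+](=O)[O-])cc1` carries a 4-nitrophenyl group on the saturated ring carbon of the shared core. In a functional assay on Ehrlich cells (Mus musculus) for cytotoxicity, read by trypan blue exclusion, with a stated time of 2 h, tested at 50 ug/mL (on this read-out higher numbers stand for a stronger effect at the one concentration tested and lower numbers for a weaker effect), compound 3 gives 10%, the lowest of the three numbers measured. Compound 1 `N#CC1=C(N)N(c2ccc(S(N)(=O)=O)cc2)C2=C(CCCC2)C1c1ccccc1`, which carries a plain phenyl group there, gives 20% in this assay, and the step of a number 10 percentage points lower from compound 1 to compound 3 (within the scatter) shows that adding the nitro group did not move the read-out beyond the scatter. Compound 2 `N#CC1=C(N)N(c2ccc(S(N)(=O)=O)cc2)C2=C(CCCC2)C1/C=C/c1ccccc1`, with a 2-phenylethenyl group in that position, gives 90%, and the step of a number 80 percentage points lower from compound 2 to compound 3 (beyond the scatter) is the only large change among these three.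

Compound 4 `N#CC1=C(N)N(c2ccc(S(N)(=O)=O)cc2)C2=C(CCCC2)C1c1ccc(Cl)c(Cl)c1` is the next compound in the series. Its change from compound 3 is 3,4-dichlorophenyl in place of 4-nitrophenyl on a saturated ring carbon. For the measured compounds named here, this exchanges one substituted phenyl ring for another on the same saturated ring carbon, and the one measured step of that kind, a number 10 percentage points lower from compound 1 to compound 3 (within the scatter), stayed within the scatter. Going by the values given here, no step bears on the 3,4-dichloro pattern itself, and the large step of a number 80 percentage points lower from compound 2 to compound 3 (beyond the scatter) concerns the 2-phenylethenyl group, which compound 4 does not carry. The expected step is therefore a number 5 percentage points higher from compound 3 to compound 4 (within the scatter), that is, no change beyond the scatter. Compound 4 is estimated to give 15% in this assay, with a likely range from 5% to 35%.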

Compound 4, a percentage reported as activity, at one concentration (the size of the read-out at that concentration, not a potency): 50%
Compound 4: the middle estimate sits 35 percentage points below what was measured; measured number above the stated range.
By their numbers in this assay, from the lowest: compounds 3 and 1 (each within the scatter of the next); then compound 4; then compound 2.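

The step of a number 40 percentage points higher from compound 3 to compound 4 (beyond the scatter) shows that in this assay the choice of substituents on a phenyl ring at this saturated ring carbon can matter, which the earlier exchange of hydrogen for nitro did not reveal. The step of a number 30 percentage points higher from compound 1 to compound 4 (beyond the scatter) adds that 3,4-dichlorophenyl also stands apart from the plain phenyl group, so adding substituents to that ring can move the read-out beyond the scatter in at least one case, while the step of a number 40 percentage points lower from compound 2 to compound 4 (beyond the scatter) places 3,4-dichlorophenyl in the middle, well short of the 2-phenylethenyl group, so the position no longer splits simply into phenyl rings with low numbers and 2-phenylethenyl with a high one. No measurement at hand gives a reason for any of these differences.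

The compounds shown leave open whether both chlorines are needed, since a single chlorine, as in 4-chlorophenyl or 3-chlorophenyl, would separate the two ring positions. They also leave open how other groups on the phenyl ring, such as methoxy, an amine or a carboxylic acid, or a longer chain in place of the ring, would compare on this read-out.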